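The source may hold more compounds than are shown below. What is called first, only, known or untested is meant among the compounds shown, and "the series" means these compounds.

Compound 1 `O=C(Nc1cc(NCc2cccs2)cc(C(F)(F)F)c1)c1cccs1` carries a (thiophen-2-yl)methyl group on a nitrogen on an aromatic ring, and in an assay on HEK293-TREx cells for antagonist activity at transient receptor potential cation channel subfamily A member 1 (Homo sapiens), read by calcium flux (on this read-out lower numbers stand for stronger inhibition and higher numbers for weaker inhibition), compound 1 gives 2700 nM. Compound 2 `COC(=O)Nc1cc(NC(=O)c2cccs2)cc(C(F)(F)F)c1` carries methoxycarbonyl on that nitrogen instead, and in this assay compound 2 gives 2300 nM. Compound 3 `CC(C)C(C)Nc1cc(NC(=O)c2cccs2)cc(C(F)(F)F)c1` carries 1,2-dimethylpropyl there, and in this assay compound 3 gives 1300 nM, the lowest of the three numbers; the step of a 1.8-fold lower number from compound 2 to compound 3 (0.25 log units; within the scatter) lies within the scatter, while the step of a 2.1-fold lower number from compound 1 to compound 3 (0.32 log units; beyond the scatter) is a modest one beyond it. Compound 4 `CCCNc1cc(NC(=O)c2cccs2)cc(C(F)(F)F)c1` has not been measured. It differs from compound 3 by propyl in place of 1,2-dimethylpropyl on a nitrogen on an aromatic ring: 1,2-dimethylpropyl leaves and propyl enters on a nitrogen on an aromatic ring whose other neighbours are aromatic carbon; cut one bond further out, (1,2-dimethylpropyl)amino becomes propylamino. The measured steps that bear on this are the three at that same nitrogen: a 1.2-fold lower number from compound 1 to compound 2 (0.07 log units; within the scatter), a 2.1-fold lower number from compound 1 to compound 3 (0.32 log units; beyond the scatter) and a 1.8-fold lower number from compound 2 to compound 3 (0.25 log units; within the scatter). Groups as unlike as (thiophen-2-yl)methyl, methoxycarbonyl and 1,2-dimethylpropyl have moved the number only a little, so the exchange of one chain for the other is expected to give no step beyond the scatter, with if anything a slightly higher number. The expected step is a 1.4-fold higher number from compound 3 to compound 4 (0.14 log units; within the scatter). For compound 4 the estimate in this assay is 1800 nM, with a range from 800 nM to 4500 nM.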

Compound 4, half-maximal inhibitory concentration: 390 nM
Estimate against measurement, compound 4: 4.6-fold (0.66 log units) above; the measured number lies below the stated range.
By their numbers in this assay, from the lowest: compound 4; then compounds 3, 2 and 1 (each within the scatter of the next, the first and the last beyond it).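

The nitrogen on an aromatic ring is less tolerant of change than the first three compounds suggested: in this assay, propyl in place of 1,2-dimethylpropyl gives a 3.3-fold lower number from compound 3 to compound 4 (0.52 log units; beyond the scatter), a larger step than any seen among those three. Propyl also stands clear of the other two groups, with a 5.9-fold lower number from compound 2 to compound 4 (0.77 log units; beyond the scatter) and a 6.9-fold lower number from compound 1 to compound 4 (0.84 log units; beyond the scatter), so compound 4 is set apart from all three earlier compounds by steps beyond the scatter. The step from compound 3 to compound 4 is notable in that neither chain has a ring, a hydrogen-bond donor or a hydrogen-bond acceptor, so a change confined to plain carbon chains is enough to shift the number at this position.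

The compounds shown leave open whether the number would go lower still with ethyl or higher with butyl or a longer chain, and whether an unbranched pentyl chain would behave like propyl or like 1,2-dimethylpropyl, which would separate chain length from branching. Nothing available here explains why propyl gives the lowest number of the four.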